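Removing one methyl group from compound 1

The source may report more compounds than this note shows. Statements on the series, on what has been measured and on what is new or still open speak of the compounds shown alone.

Measured in a functional assay on A549 cells (Homo sapiens) for antiproliferative activity, read by MTT assay, with a stated time of 72 h; on this read-out higher numbers stand for weaker inhibition and lower numbers for stronger inhibition:
Compound 1 `COc1ncc(-c2ccc3c(c2)N(c2ccc(C)cc2)C(=O)CO3)cc1NS(=O)(=O)c1ccc(F)cc1` gives 5870 nM
Compound 2 `COc1ccc(N2C(=O)COc3ccc(-c4ccc(O)cc4)cc32)cc1` gives > 40000 nM
Compound 3 `CC(C)N1C(=O)COc2ccc(-c3cnc(Cl)c(NS(=O)(=O)c4ccc(F)cc4)c3)cc21` gives 5100 nM

Compound 1, at 5870 nM, and compound 3, at 5100 nM, lie within the scatter of each other in this assay. Compound 2 reads > 40000 nM, which is a limit and not a number. Compound 4 `COc1ncc(-c2ccc3c(c2)N(c2ccccc2)C(=O)CO3)cc1NS(=O)(=O)c1ccc(F)cc1` turns 4-methylphenyl into phenyl, with hydrogen in place of methyl on an aromatic carbon, para to a large group: hydrogen in place of methyl on an aromatic carbon. Going by the values given here, no measured pair shows this change alone, so the expectation starts from compound 1 at 5870 nM. The expected size of the change, a 1.1-fold lower number from compound 1 to compound 4 (0.03 log units; within the scatter), stays within the scatter, with no direction expected. Compound 4 is estimated at 5500 nM within a range from 2400 nM to 13000 nM.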

Compound 4, half-maximal inhibitory concentration: 3490 nM
Compound 4: the middle estimate sits 1.6-fold (0.20 log units) above what was measured; the measured number falls inside the stated range.
By their numbers in this assay, from the lowest: compounds 4, 3 and 1 (each within the scatter of the next). At a limit, above all of these: compound 2.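

In this assay, hydrogen in place of methyl on an aromatic carbon, para to a large group, gives a 1.7-fold lower number from compound 1 to compound 4 (0.23 log units; within the scatter). This is the first step shown at this position, and it indicates that the methyl of the 4-methylphenyl group can be lost without a change beyond the scatter. No measurement shown bears on a cause for this step. From the compounds shown here alone, whether an amine or a carboxylic acid at this position would leave the number equally unmoved stays open. So does whether any group here can move it beyond the scatter.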